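From Furan to Fluorophenyl: Estimating Compound 4

The source may report more compounds than this note shows. Statements on the series, on what has been measured and on what is new or still open speak of the compounds shown alone.

Compound 1 `Cc1nc(-c2ccc(Cl)cc2)c(CC(=O)O)s1` gives 41000 nM
Compound 2 `O=C(O)Cc1sc(C(c2ccc(F)cc2)c2ccc(F)cc2)nc1-c1ccco1` gives 140 nM
Compound 3 `O=C(O)Cc1sc(C(c2ccccc2)c2ccc(Cl)cc2)nc1-c1ccc(Cl)cc1` gives 75 nM

In an in vitro functional assay on HEK285-7 cells for antagonist activity at prostaglandin D2 receptor 2 (Homo sapiens), read by BRET and beta-arrestin recruitment (a higher number here means a weaker inhibitor, a lower number a stronger inhibitor), compound 2 holds the second highest of the three numbers. Compound 3 sits nearest, with a value within the usual scatter of that of compound 2, while compound 1 lies far above both. Compound 4 `O=C(O)Cc1sc(C(c2ccc(F)cc2)c2ccc(F)cc2)nc1-c1cccc(F)c1` is obtained from compound 2 by one change: 3-fluorophenyl in place of furan-2-yl on an aromatic carbon. Among the measured compounds shown here, no step between measured compounds tracks this change directly; compound 3 merely shows that a six-membered carbon ring at this place sits alongside a furan within the scatter. Compound 4 is therefore expected to show no step beyond the scatter, perhaps a slightly lower number, as a 1.4-fold lower number from compound 2 to compound 4 (0.15 log units; within the scatter). The estimate for compound 4 in this assay is 100 nM, between 35 nM and 300 nM.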

Compound 4, half-maximal inhibitory concentration: 18 nM
Compound 4: middle estimate off by 5.6-fold (0.74 log units), on the high side; the whole stated range lies above it.
By their numbers in this assay, from the lowest: compound 4; then compounds 3 and 2 (each within the scatter of the next); then compound 1.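

In this assay, 3-fluorophenyl in place of furan-2-yl on this aromatic carbon gives a 7.8-fold lower number from compound 2 to compound 4 (0.89 log units; beyond the scatter) and so provides the first step read directly at this place. It shows that the group held here, next to the ring nitrogen, can move the number beyond the scatter. No measurement at hand explains this step. Going by these compounds, whether it follows from the fluorine or from the six-membered ring of carbon remains open. So does how a plain phenyl, a pyridyl or a 3-methoxyphenyl group would read here.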